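Trifluoromethyl gives way to bromo in compound 3

The source may hold more compounds than are shown below. What is called first, only, known or untested is meant among the compounds shown, and "the series" means these compounds.

In a functional assay on HeLa cells (Homo sapiens) for inhibition, read by MTT assay, with a stated time of 72 h (a higher number here means a weaker inhibitor, a lower number a stronger inhibitor), compound 3 `COc1cc(NC(C)CCCNC(=O)NNC(=O)Nc2ccc(C(F)(F)F)cc2)c2ncccc2c1` gives 15000 nM, the lowest number measured in the set. Compound 1 `COc1cc(NC(C)CCCNC(=O)Nc2cccc(Cl)c2)c2ncccc2c1` gives 17000 nM, which lies within the scatter of it. For compound 2 `COc1cc(NC(C)CCCNC(=O)NNC(=O)Nc2ccc(F)cc2)c2ncccc2c1` the result is only a limit, >= 250000 nM.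

Compound 4 `COc1cc(NC(C)CCCNC(=O)NNC(=O)Nc2ccc(Br)cc2)c2ncccc2c1` carries bromo in place of trifluoromethyl on an aromatic carbon. The relevant precedent is an at least 16-fold lower number from compound 2 to compound 3 (1.22 log units; beyond the scatter), made by trifluoromethyl replacing fluoro at this same place, so this site can matter greatly. The step of an at least 14-fold higher number from compound 1 to compound 2 (1.16 log units; beyond the scatter) changes another part and bears little. Only a small 1.7-fold higher number from compound 3 to compound 4 (0.22 log units; within the scatter) is expected, toward a higher number, perhaps none beyond the scatter. Compound 4 is estimated at 25000 nM, with an expected range of 10000 nM to 120000 nM.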

Compound 4, half-maximal inhibitory concentration: 101000 nM
Estimate against measurement, compound 4: 4.0-fold (0.61 log units) below, and the stated range covers the measured number.
By their numbers in this assay, from the lowest: compounds 3 and 1 (each within the scatter of the next); then compound 4. At a limit, above all of these: compound 2.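

Bromo does not stand in for trifluoromethyl on this aromatic carbon (a 6.7-fold higher number from compound 3 to compound 4 (0.83 log units; beyond the scatter)), so this site separates the two groups, which the earlier compounds could not show. Bromo still reads lower than fluoro here (an at least 2.4-fold lower number from compound 2 to compound 4 (0.39 log units; beyond the scatter)), a step that rests on a limit for compound 2, which gives the order trifluoromethyl, bromo, fluoro across these three compounds. Compound 4 also stands apart from compound 1 (a 5.9-fold higher number from compound 1 to compound 4 (0.77 log units; beyond the scatter)), whereas compound 3 lay within the scatter of compound 1. Going by these compounds, whether that order extends to a nitrile or a methoxy group on this carbon stays open. So does how an amine there would read.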